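The source may hold more compounds than are shown below. What is called first, only, known or untested is meant among the compounds shown, and "the series" means these compounds.

Within the data shown here, compound 1 `Cc1nn(C)c2c1C(c1ccccc1)=NCC(=O)N2` gives 10 mg/kg in a functional assay on the whole organism (strain Holtzman) with Rattus norvegicus as the target (a higher number here means that more compound is needed for the effect, a lower number that less compound is needed), the second highest of the three numbers known here: compound 2 `CCc1nn(C)c2c1C(c1ccccc1)=NCC(=O)N2` gives 2.5 mg/kg, and compound 3 `Cn1nc(Cl)c2c1NC(=O)CN=C2c1ccccc1` gives 40 mg/kg. The change to compound 4 `Cc1nn(-c2ccccc2)c2c1C(c1ccccc1)=NCC(=O)N2` is phenyl in place of methyl on an aromatic nitrogen, on an aromatic nitrogen of the five-membered ring in the shared core. Neither measured step touches that position: a 4.0-fold lower number from compound 1 to compound 2 (0.60 log units; beyond the scatter) and a 4.0-fold higher number from compound 1 to compound 3 (0.60 log units; beyond the scatter) both concern the substituent on an aromatic carbon, so they show that the core answers to small changes but say nothing about the ring nitrogen. Among the measured compounds shown here, with no step bearing on it, compound 4 is expected to lie close to its parent, with a step of no change at the digits printed from compound 1 to compound 4 (within the scatter) and an estimate of 10 mg/kg, ranging from 3 mg/kg to 40 mg/kg.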

Compound 4, minimum effective dose: > 40 mg/kg
Compound 4 ended at the assay's limit (the forecaster's own chance of this, stated with the estimate: 10%); at least 4.0-fold (0.60 log units) between middle value and limit.
By their numbers in this assay, from the lowest: compound 2; then compound 1; then compound 3.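

Among these compounds, until now, no compound showed whether the aromatic nitrogen of the five-membered ring tolerates change. It does not tolerate this one: phenyl in place of methyl gives an at least 4.0-fold higher number from compound 1 to compound 4 (0.60 log units; beyond the scatter) in this assay. The value for compound 4 is a limit of the assay, not a number, so the true size of this step stays unknown: the limit of > 40 mg/kg in this assay, at which 1 of the 4 values shown sits.

A single replacement leaves open how an ethyl group or a longer chain would behave on this nitrogen. On these data alone, a benzyl group there is equally open, as is a bare hydrogen.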